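From Phenyl to Hydrogen on a Ring Nitrogen

The source may report more compounds than this note shows. Statements on the series, on what has been measured and on what is new or still open speak of the compounds shown alone.

Of the compounds shown here, two built on the same shared core have been tested in a functional assay on A-375 cells (Homo sapiens) for antiproliferative activity, read by trypan blue exclusion, with a stated time of 48 h, tested at 10 uM; on this read-out lower numbers stand for a stronger effect and higher numbers for a weaker effect at the one concentration tested. Compound 1 `CCCCCCC#Cc1ccc(S(=O)(=O)Nc2cccc(-c3csc(NC(C)=O)n3)c2)cc1` carries an acetyl group on a nitrogen on an aromatic ring, and in this assay compound 1 gives 5.8%. Compound 2 `CCCCCCC#Cc1ccc(S(=O)(=O)Nc2cccc(-c3csc(Nc4ccccc4)n3)c2)cc1` carries a phenyl group on that nitrogen instead, and in this assay compound 2 gives 5.8%. The step of no change at the digits printed from compound 1 to compound 2 (within the scatter) shows that exchanging acetyl for phenyl left the read-out where it was, so compound 2 stands level with compound 1.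

Compound 3 `CCCCCCC#Cc1ccc(S(=O)(=O)Nc2cccc(-c3csc(N)n3)c2)cc1` removes that phenyl altogether: hydrogen in place of phenyl on a nitrogen on an aromatic ring. Within the data shown here, no measured step covers the loss of a substituent at this nitrogen; the only step that bears on the position is no change at the digits printed from compound 1 to compound 2 (within the scatter), and it was flat. A bare hydrogen is expected to leave the read-out close to that of compound 2, because the step of no change at the digits printed from compound 1 to compound 2 (within the scatter) showed no sensitivity to what sits on this nitrogen, so the expected step is a number 2.2 percentage points higher from compound 2 to compound 3 (within the scatter). Compound 3 is therefore estimated at 8%, within a range from 3% to 25%.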

Compound 3, a percentage reported as activity, at one concentration (the size of the read-out at that concentration, not a potency): 3.5%
Estimate against measurement, compound 3: 4.5 percentage points above, and the stated range covers the measured number.
By their numbers in this assay, from the lowest: compounds 3, 1 and 2 (each within the scatter of the next).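

In this assay, replacing the phenyl on the nitrogen with hydrogen gives a number 2.3 percentage points lower from compound 2 to compound 3 (within the scatter) and replacing the acetyl with hydrogen gives a number 2.3 percentage points lower from compound 1 to compound 3 (within the scatter) so the read-out does not separate the free amino compound from either substituted one. The earlier pair showed only that one substituent could stand in for another on this nitrogen, whereas these steps show that, at the one concentration tested and among these three compounds, neither substituent is needed to keep the read-out within the scatter. No measurement shown here explains this lack of separation at the nitrogen.

On these data alone, a single concentration gives the size of the effect and not a potency, so it remains open whether these three compounds would differ if tested across a range of concentrations. As far as these compounds go, it is also open whether a benzyl group, a longer acyl chain or a carboxylic acid on this nitrogen would leave the read-out in the same place, or whether this tolerance ends with larger or charged groups.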